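A diol side chain replacing a basic amine

The compounds below may be only part of what the source reports. "The series", "measured", "known", "first", "only" and "open" are said of these compounds alone.

Compound 1 `N#Cc1ccc(Cn2nc(-c3cc(Cl)c(NC[C@H](O)CO)nc3F)c3ccccc3c2=O)cc1`: > 100000 nM (a limit of the assay)
Compound 2 `CN(C)CCNc1nc(F)c(-c2nn(Cc3ccc(C#N)cc3)c(=O)c3ccccc23)cc1Cl`: 9760 nM

Within the data shown here, in an ADME assay on HepG2 2.2.15 cells (Homo sapiens) for cytotoxicity, read by MTT assay, with a stated time of 8 days (a higher number here means that more compound is tolerated, a lower number that less compound is tolerated), compound 2 gives 9760 nM, the only exact number so far. Compound 1 gives only a limit, > 100000 nM.

Compound 3 `N#Cc1ccc(Cn2nc(-c3cc(Cl)c(NC[C@@H](O)CO)nc3F)c3ccccc3c2=O)cc1` changes the side chain of compound 2: 1,2-dihydroxyethyl in place of (dimethylamino)methyl on a saturated chain carbon bound to a nitrogen on an aromatic ring. Here, 1,2-dihydroxyethyl takes the place of (dimethylamino)methyl on a saturated chain carbon bound to a nitrogen on an aromatic ring. Compound 1 also carries 1,2-dihydroxyethyl, so one measured step bears on this change, and it ran the opposite way. Read in reverse, an at least 10-fold lower number from compound 1 to compound 2 (1.01 log units; beyond the scatter) leads to the expectation of a large rise in this assay, with more compound tolerated. The expected size is a 10-fold higher number from compound 2 to compound 3 (1.01 log units; beyond the scatter). For compound 3 the estimated value is 100000 nM, with a range of 40000 nM to 250000 nM.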

Compound 3, half-maximal cytotoxic concentration: > 100000 nM
Compound 3 gave a limit, no number; the forecaster's own chance of this, stated with the estimate: 80%; the middle value lies on the limit itself.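

In this assay, 1,2-dihydroxyethyl in place of (dimethylamino)methyl gives an at least 10-fold higher number from compound 2 to compound 3 (1.01 log units; beyond the scatter), so the large rise seen earlier does not depend on one drawn configuration of the diol side chain: the fact that compounds 1 and 3 differ only in the configuration as drawn

Compound 3 gives only a limit of the assay, > 100000 nM, and not a number.

The step between compound 1 and compound 3 cannot be read, and neither configuration can be placed ahead of the other, for one reason: the limit of > 100000 nM in this assay, at which 2 of the 3 values shown sit.

From the compounds shown here alone, how much more of either diol the cells would tolerate stays open. Also open, going by these compounds, is whether the rise needs both hydroxyl groups, or whether a single hydroxyl group, a methoxy group or a carboxylic acid on this saturated chain carbon would give the same result.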